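The source may report more compounds than this note shows. Statements on the series, on what has been measured and on what is new or still open speak of the compounds shown alone.

Three compounds share one core and differ only in the amide. In an assay on isolated protein for inhibition of thyroid hormone receptor beta (Homo sapiens), read by fluorescence, with a stated time of 30 min (a higher number here means a weaker inhibitor, a lower number a stronger inhibitor), compound 1 `COc1cc(C(=O)N2CCCC2)cc2nc(NCc3cccc(Cl)c3)oc12` gives 180 nM, compound 2 `COc1cc(C(=O)N2CCCC2(C)C)cc2nc(NCc3cccc(Cl)c3)oc12` gives 47 nM, and compound 3 `COc1cc(C(=O)N2CCC(O)C(C)C2)cc2nc(NCc3cccc(Cl)c3)oc12` gives 25 nM, the lowest number shown, though one step is a 1.9-fold lower number from compound 2 to compound 3 (0.27 log units; within the scatter) while a 7.2-fold lower number from compound 1 to compound 3 (0.86 log units; beyond the scatter). Compound 4 `COc1cc(C(=O)N2CCC(O)C(C)C2)cc2nc(NC3(c4cccc(Cl)c4)CC3)oc12` differs from compound 3 at the other end of the molecule: 1-(3-chlorophenyl)cyclopropyl in place of 3-chlorobenzyl on a nitrogen on an aromatic ring. Among the compounds with values here, no measured step touches that part; a 3.8-fold lower number from compound 1 to compound 2 (0.58 log units; beyond the scatter) and a 7.2-fold lower number from compound 1 to compound 3 (0.86 log units; beyond the scatter) concern the amide alone, so nothing here sets the direction. The step in this assay is therefore expected to be a 1.2-fold higher number from compound 3 to compound 4 (0.08 log units; within the scatter), with a wide range. Compound 4 is estimated at 30 nM, between 8 nM and 110 nM.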

Compound 4, half-maximal inhibitory concentration: 120 nM
For compound 4 the middle estimate is 4.0-fold (0.60 log units) below the measured one; measured number outside the range, above it.
By their numbers in this assay, from the lowest: compounds 3 and 2 (each within the scatter of the next); then compounds 4 and 1 (each within the scatter of the next).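

In this assay the group on the nitrogen matters as well as the amide: 1-(3-chlorophenyl)cyclopropyl in place of 3-chlorobenzyl gives a 4.8-fold higher number from compound 3 to compound 4 (0.68 log units; beyond the scatter) with the amide held the same. The entering group adds a three-membered ring of carbon only, with no hydrogen-bond donors or acceptors on either group, and the inhibitor becomes weaker. Nothing available explains this step.

On these data alone, it remains open whether a 1-(3-chlorophenyl)ethyl group would give a similar step, and whether the step would hold with the 2,2-dimethylpyrrolidin-1-yl amide.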